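From Bromo to Methoxy: Expected Cytotoxicity

The source may hold more compounds than are shown below. What is called first, only, known or untested is meant among the compounds shown, and "the series" means these compounds.

Compound 3 `O=C(N/N=C/c1ccc(Br)cc1)c1cnccn1` gives 94% in an ADME assay on J774 cells (Mus musculus) for cytotoxicity, read by MTT assay, with a stated time of 48 h, tested at 150 ug/mL (a higher number here means a weaker effect of the compound at the concentration tested, a lower number a stronger effect), the second highest of three numbers. Compound 1 `O=C(N/N=C/c1ccccc1)c1cnccn1` gives 100%, and a number 6 percentage points lower from compound 1 to compound 3 (within the scatter). Compound 2 `O=C(N/N=C/c1ccc(F)cc1)c1cnccn1` gives 71%, and a number 23 percentage points higher from compound 2 to compound 3 (beyond the scatter). Compound 4 `COc1ccc(/C=N/NC(=O)c2cnccn2)cc1` differs from compound 3 in one place: methoxy in place of bromo on an aromatic carbon. Only the two steps that end at compound 3 bear on this change, one within the scatter and the other modest, and neither involves methoxy, so no firm direction can be read from them. A step of a number 4 percentage points lower from compound 3 to compound 4 (within the scatter) is therefore expected, staying within the scatter. Compound 4 is expected to give 90%, with a range from 70% to 100%.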

Compound 4, a percentage reported as activity, at one concentration (the size of the read-out at that concentration, not a potency): 55%
Beside the measured number, compound 4's estimate is 35 percentage points above it; the measured number lies below the stated range.
By their numbers in this assay, from the lowest: compound 4; then compound 2; then compounds 3 and 1 (each within the scatter of the next).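

Going by these compounds alone, at this place on the ring, the choice of group matters far more than the earlier compounds showed: in this assay methoxy gives a number 39 percentage points lower from compound 3 to compound 4 (beyond the scatter) and a number 45 percentage points lower from compound 1 to compound 4 (beyond the scatter), both large, whereas bromo stayed within the scatter of hydrogen. Methoxy also goes beyond fluoro, with a number 16 percentage points lower from compound 2 to compound 4 (beyond the scatter), so compound 4 has the lowest number of the four. No measurement here explains why this happens. As far as these compounds go, what an amine or a hydroxyl would give at this place stays open, as does whether a longer chain such as ethoxy would lower the number further.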